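Indazole in place of the azaindazole ring system

The compounds below may be only part of what the source reports. "The series", "measured", "known", "first", "only" and "open" are said of these compounds alone.

Compound 3 `CC/C(=C(/c1ccc(/C=C/C(=O)O)cc1)c1cc2cn[nH]c2cn1)c1ccccc1` gives the highest number of the three measured compounds in a functional assay on MCF7 cells (Homo sapiens) for cytotoxicity, read by CellTiter-Glo, with a stated time of 5 days; on this read-out lower numbers stand for stronger inhibition and higher numbers for weaker inhibition: compound 3 gives 442 nM, while compound 1 `O=C(O)/C=C/c1ccc(/C(=C(/CCF)c2ccccc2)c2ccc3[nH]ncc3c2)cc1` gives 2.1 nM and compound 2 `O=C(O)/C=C/c1ccc(/C(=C(\c2ccccc2)C(F)F)c2ccc3[nH]ncc3c2)cc1` gives 14 nM. Compound 4 `CC/C(=C(/c1ccc(/C=C/C(=O)O)cc1)c1ccc2[nH]ncc2c1C)c1ccccc1` differs from compound 3 by a group of 10 heavy atoms (8 carbon, 2 nitrogen; one five-membered aromatic ring with 2 hetero atoms, one six-membered aromatic ring of carbon only) in place of a group of 9 heavy atoms (6 carbon, 3 nitrogen; one five-membered aromatic ring with 2 hetero atoms, one six-membered aromatic ring with 1 hetero atom), on a double-bonded chain carbon bound to an aromatic carbon and a double-bonded chain carbon. Among the measured compounds shown here, the only measured step, a 6.7-fold higher number from compound 1 to compound 2 (0.82 log units; beyond the scatter), concerns the fluorinated chain and does not bear on this exchange. Compound 1 carries a ring system of the same kind as the entering group, without the methyl, and its number in this assay lies far under that of compound 3. He therefore expects a marked fall, a 22-fold lower number from compound 3 to compound 4 (1.34 log units; beyond the scatter), and estimates compound 4 at 20 nM, with a range from 4 nM to 100 nM.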

Compound 4, half-maximal inhibitory concentration: 50 nM
Compound 4: the middle estimate sits 2.5-fold (0.40 log units) below what was measured, within the range that was stated.
By their numbers in this assay, from the lowest: compound 1; then compound 2; then compound 4; then compound 3.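

With the rest of the structure unchanged, the exchange for 4-methyl-1H-indazol-5-yl on a double-bonded chain carbon bound to an aromatic carbon and a double-bonded chain carbon gives, in this assay, an 8.8-fold lower number from compound 3 to compound 4 (0.95 log units; beyond the scatter) and so the first measured effect of changing this ring group; the earlier step concerned only the fluorinated chain. Nothing given here accounts for the size of this step.

The compounds shown leave open how much of the step belongs to the methyl and how much to the ring exchange. They also leave open whether a chlorine atom or a methoxy group in place of that methyl would give a similar number.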